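From isopropyl to hydroxymethyl: a cytotoxicity estimate for compound 3

The source may report more compounds than this note shows. Statements on the series, on what has been measured and on what is new or still open speak of the compounds shown alone.

Compound 1 `CC(S)C(=O)N[C@@H](C)C(=O)O` gives 20200000 nM
Compound 2 `CC(S)C(=O)N[C@H](C(=O)O)C(C)C` gives 14200000 nM

Among the measured compounds shown here, both values come from a functional assay on MCF7 cells (Homo sapiens) for cytotoxicity, read by MTT assay, with a stated time of 72 h (on this read-out higher numbers stand for weaker inhibition and lower numbers for stronger inhibition), and are the only measurements so far. Compound 2 stands at 14200000 nM and lies within the scatter of compound 1, so the two cannot be ranked.

Compound 3 `CC(S)C(=O)N[C@@H](CO)C(=O)O` has not yet been measured. Its difference from compound 2 is hydroxymethyl in place of isopropyl on a saturated chain carbon bound to an amide-type nitrogen and a carbonyl carbon and it falls on a saturated chain carbon bound to an amide-type nitrogen and a carbonyl carbon. For the measured compounds named here, one measured step bears on this change, a 1.4-fold lower number from compound 1 to compound 2 (0.15 log units; within the scatter) at that same place. Going by the values given here, no measured compound carries hydroxymethyl, so the data give no direct reading of that group. Among the compounds with values here, with this one step as the only guide, no shift beyond the scatter is expected in this assay and no firm direction can be claimed. The estimated step is a 1.2-fold higher number from compound 2 to compound 3 (0.08 log units; within the scatter) and it is expected to stay within the scatter. Compound 3 is expected at 17000000 nM with an estimated range from 8000000 nM to 35000000 nM in this read-out.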

Compound 3, half-maximal inhibitory concentration: 1300000 nM
The estimate for compound 3 lay 13-fold (1.12 log units) above the measured number, outside the stated range (below it).
By their numbers in this assay, from the lowest: compound 3; then compounds 2 and 1 (each within the scatter of the next).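

In this assay the saturated chain carbon bound to an amide-type nitrogen and a carbonyl carbon turned out to be a place where a change can move the read-out: methyl and isopropyl could not be told apart there, yet hydroxymethyl in place of isopropyl gives an 11-fold lower number from compound 2 to compound 3 (1.04 log units; beyond the scatter) at that same place. Hydroxy in place of hydrogen on a saturated chain carbon, two bonds along the chain from an amide-type nitrogen and a carbonyl carbon, gives a 16-fold lower number from compound 1 to compound 3 (1.19 log units; beyond the scatter) as well, which puts compound 3 lowest of the three, with both its steps beyond the scatter. No measurement at hand bears on why hydroxymethyl stands so far from the other two groups.

Three compounds cannot tell whether the step belongs to the hydroxy group itself or would also appear with an aminomethyl group, a methoxymethyl group or a carboxylic acid on a short chain at this place. Going by these compounds, it also stays open whether a longer chain ending in hydroxy would keep, lose or extend the step seen with hydroxymethyl.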